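From 4-fluorophenyl to 3-fluorophenyl in compound 2

The compounds below may be only part of what the source reports. "The series", "measured", "known", "first", "only" and "open" are said of these compounds alone.

Measured in a functional assay on HL-60 cells (Homo sapiens) for inhibition, read by MTT assay, with a stated time of 72 h; on this read-out higher numbers stand for weaker inhibition and lower numbers for stronger inhibition:
- compound 1 `Cc1nc(-c2ccccc2F)c(C(=O)N2CCN(c3cc(Cl)cc(Cl)c3)CC2)o1`: 60.2 nM
- compound 2 `Cc1nc(-c2ccc(F)cc2)c(C(=O)N2CCN(c3cc(Cl)cc(Cl)c3)CC2)o1`: 52.1 nM
- compound 3 `COc1cc(OC)cc(N2CCN(C(=O)c3oc(C)nc3-c3ccc(F)cc3)CC2)c1`: 38.5 nM

Compound 2 lies within the scatter of both other measured compounds. Compound 4 `Cc1nc(-c2cccc(F)c2)c(C(=O)N2CCN(c3cc(Cl)cc(Cl)c3)CC2)o1` has the same atoms as compound 2, joined differently: 3-fluorophenyl in place of 4-fluorophenyl on an aromatic carbon. The closest guide is the exchange of 2-fluorophenyl for 4-fluorophenyl, a 1.2-fold lower number from compound 1 to compound 2 (0.06 log units; within the scatter). The exchange of 3,5-dichlorophenyl for 3,5-dimethoxyphenyl, a 1.4-fold lower number from compound 2 to compound 3 (0.13 log units; within the scatter), lies at a different place and bears on this change only indirectly. Neither measured step leaves the scatter, so no step beyond the scatter is expected in this assay. The expected step is a 1.0-fold lower number from compound 2 to compound 4 (0.02 log units; within the scatter). Compound 4 is estimated at 50 nM, with an expected range from 25 nM to 105 nM.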

Compound 4, half-maximal inhibitory concentration: 41.7 nM
Estimate against measurement, compound 4: 1.2-fold (0.08 log units) above; the measured number falls inside the stated range.
By their numbers in this assay, from the lowest: compounds 3, 4, 2 and 1 (each within the scatter of the next).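

In this assay the step of a 1.2-fold lower number from compound 2 to compound 4 (0.10 log units; within the scatter) and the step of a 1.4-fold lower number from compound 1 to compound 4 (0.16 log units; within the scatter) both stay within the scatter, so all three fluorophenyl isomers can now be compared at this position, and none stands apart from the others. The earlier compounds shown here showed only the exchange between 2-fluorophenyl and 4-fluorophenyl, whereas 3-fluorophenyl now completes the set without a readable difference. Nothing available offers an explanation for this result. Still open, as far as these compounds go, is whether a group other than fluorophenyl at this position, such as a pyridyl ring or a phenyl bearing a carboxylic acid, would shift the number. Also open, from the compounds shown here alone, is how 3-fluorophenyl fares alongside 3,5-dimethoxyphenyl.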